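Urea series: fluoro to hydrogen on the aromatic ring

A few compounds are considered here, and "the series" means these few. Any claim that something is new, unique, unknown or untested is made for them only; others in the source may bear on it.

Measured so far in a functional assay on A-375 cells (Homo sapiens) for inhibition; on this read-out lower numbers stand for stronger inhibition and higher numbers for weaker inhibition:
- compound 1, `CCCCNC(=O)N1CC1C#N`: 15000 nM
- compound 2, `N#CC1CN1C(=O)Nc1ccc(F)cc1`: 3400 nM
- compound 3, `N#CC1CN1C(=O)Nc1ccc(Cl)cc1Cl`: reported only as a limit, > 39000 nM

Compound 2 gives the lower of the two numeric values in this assay; compound 1 gives a higher number, and that gap lies beyond the usual scatter. Compound 3 sits at the limit of > 39000 nM in this assay, at which 1 of the 3 values shown sits, so its value is a limit and not a number, and it adds no ranking information against the other two.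

Compound 4, `N#CC1CN1C(=O)Nc1ccccc1`, is the next point. It differs from compound 2 by hydrogen in place of fluoro on an aromatic carbon. For the measured compounds named here, no step between measured compounds covers this change, so the expectation rests on compound 2 alone. A change of one fluorine for hydrogen on the six-membered aromatic ring of carbon only is expected to move this assay little, within the scatter or at most a small shift toward a higher number. Compound 4 is therefore estimated at 5000 nM, with a range of 1700 nM to 15000 nM, which amounts to an expected step of a 1.5-fold higher number from compound 2 to compound 4 (0.17 log units; within the scatter).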

Compound 4, half-maximal inhibitory concentration: 11000 nM
The estimate for compound 4 lay 2.2-fold (0.34 log units) below the measured number; the range from low to high includes it.
By their numbers in this assay, from the lowest: compound 2; then compounds 4 and 1 (each within the scatter of the next). At a limit, above all of these: compound 3.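

In this assay, for the compounds shown here, hydrogen in place of fluoro on an aromatic carbon gives a 3.2-fold higher number from compound 2 to compound 4 (0.51 log units; beyond the scatter), the first reading of a change at a single place. The aromatic carbon para to a group of 8 heavy atoms is therefore not a neutral site: exchanging one fluorine for hydrogen, with the rest of the structure unchanged, moves the number beyond the scatter. The step is modest, and the fluoro compound has the lower number, although this rests on a single pair.

Open, on these data alone, is how other groups on this same aromatic carbon would read, such as chloro alone, methoxy, an amine or a carboxylic acid, and whether the step holds with a longer chain in place of the aromatic ring. No measured property among the compounds shown bears on this step.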